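A few compounds are considered here, and "the series" means these few. Any claim that something is new, unique, unknown or untested is made for them only; others in the source may bear on it.

Going by the values given here, compound 1 `CN1CCN(c2nc(-c3cccc(Cl)c3)nc3[nH]cnc23)CC1` is the first of three measured compounds in this study. In an assay on cells for displacement of a labelled ligand from adenosine receptor A3 (Homo sapiens), read by scintillation counting and radioligand binding, with a stated time of 180 min (a lower number here means a stronger inhibitor, a higher number a weaker inhibitor), compound 1 gives 100 nM. Compound 2 `CN1CCN(c2nc(-c3cc(Cl)ccc3Cl)nc3[nH]cnc23)CC1` carries one more chloro group than compound 1, and in this assay compound 2 gives 251 nM. Compound 3 `Clc1ccc(Cl)c(-c2nc(N3CCCCC3)c3nc[nH]c3n2)c1` keeps the 2,5-dichlorophenyl group of compound 2 but has a different ring on the shared core; in this assay compound 3 gives 200 nM. The two cores differ as follows: piperidin-1-yl in place of 4-methylpiperazin-1-yl on an aromatic carbon. This exchange made a 1.3-fold lower number from compound 2 to compound 3 (0.10 log units; within the scatter), so the two compounds cannot be told apart on this measurement.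

Compound 4 `Clc1cccc(-c2nc(N3CCCCC3)c3nc[nH]c3n2)c1` has not yet been measured. It differs from compound 3 in one place: hydrogen in place of chloro on an aromatic carbon. The same change was already made once among the measured compounds, from compound 2 to compound 1: hydrogen in place of chloro on an aromatic carbon. Both changes sit at a place described in the same words, so the change is the same. Removing that chloro group gave a 2.5-fold lower number from compound 2 to compound 1 (0.40 log units; beyond the scatter).

For compound 4 a step of similar size is expected, a 2.5-fold lower number from compound 3 to compound 4 (0.40 log units; beyond the scatter), because the step from compound 2 to compound 1 was a 2.5-fold lower number from compound 2 to compound 1 (0.40 log units; beyond the scatter) and compound 4 starts from compound 3 at 200 nM. The estimated value for compound 4 is therefore 80 nM, with a likely range from 40 nM to 160 nM.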

Compound 4, inhibition constant: 39.8 nM
For compound 4 the middle estimate is 2.0-fold (0.30 log units) above the measured one; measured number outside the range, below it.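

Going by these compounds alone, removing the chloro group gave a 5.0-fold lower number from compound 3 to compound 4 (0.70 log units; beyond the scatter) in this assay, and this agrees in direction with the step seen on the other core, while the gap in size between the two steps is no more than scatter: the same change on two cores in this assay, a 2.5-fold lower number (0.40 log units; beyond the scatter) from compound 2 to compound 1 and a 5.0-fold lower number (0.70 log units; beyond the scatter) from compound 3 to compound 4, 2.0-fold (0.30 log units) apart, within the scatter of two such steps The exchange of rings gives a similar picture, with a 2.5-fold lower number from compound 1 to compound 4 (0.40 log units; beyond the scatter) beyond the scatter although the same exchange on the dichloro pair was not, yet these two steps cannot be told apart either: the same change on two cores in this assay, a 1.3-fold lower number (0.10 log units; within the scatter) from compound 2 to compound 3 and a 2.5-fold lower number (0.40 log units; beyond the scatter) from compound 1 to compound 4, 2.0-fold (0.30 log units) apart, within the scatter of two such steps Within these four compounds, then, each change carries from one core to the other and the two changes can be treated as roughly additive, but this rests on only two pairs per change in one assay, so it neither establishes a rule for other cores nor explains why the numbers move.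

The compounds shown leave open whether the chloro group that remains in all four could be exchanged for fluoro or methoxy with any gain. They also leave open how a morpholin-4-yl ring or an open-chain amine on the shared core would behave, and whether removing the chloro group would give a similar step there.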